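The source may hold more compounds than are shown below. What is called first, only, known or untested is meant among the compounds shown, and "the series" means these compounds.

Measured in an ADME assay on the whole organism (Rattus norvegicus), at a dose of 2 mg/kg by the oral route; on this read-out higher numbers stand for higher exposure at the dose given and lower numbers for lower exposure:
- Compound 1 `COc1cc(OCc2cccc(-c3cnc(OC)nc3)c2)c2cc(-c3cn4nc(OC)sc4n3)oc2c1`: 1030 ng.h/mL
- Compound 2 `COc1ccc(-c2cccc(COc3cc(OC)cc4oc(-c5cn6nc(OC)sc6n5)cc34)c2)nc1`: 1700 ng.h/mL

Compound 2, at 1700 ng.h/mL, stands within the scatter of compound 1. Compound 3 `COc1cc(OCc2cccc(-c3ccc(C#N)cc3)c2)c2cc(-c3cn4nc(OC)sc4n3)oc2c1` differs from compound 2 in one place: 4-cyanophenyl in place of 5-methoxypyridin-2-yl on an aromatic carbon. For the measured compounds named here, the only measured step that bears on this is a 1.7-fold higher number from compound 1 to compound 2 (0.22 log units; within the scatter), where 5-methoxypyridin-2-yl took the place of 2-methoxypyrimidin-5-yl. Going by the values given here, no measured compound carries 4-cyanophenyl, so the evidence is thin, and no change beyond the scatter is expected in this assay. The expected step is a 1.3-fold lower number from compound 2 to compound 3 (0.12 log units; within the scatter). The estimate for compound 3 is 1300 ng.h/mL, with an expected range of 450 ng.h/mL to 3600 ng.h/mL.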

Compound 3, area under the concentration-time curve: 610 ng.h/mL
For compound 3 the middle estimate is 2.1-fold (0.33 log units) above the measured one, within the range that was stated.
By their numbers in this assay, from the lowest: compounds 3, 1 and 2 (each within the scatter of the next, the first and the last beyond it).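

In this assay, the place on the carbon-only aromatic ring now shows a change beyond the scatter: replacing 5-methoxypyridin-2-yl with 4-cyanophenyl gives a 2.8-fold lower number from compound 2 to compound 3 (0.45 log units; beyond the scatter). Replacing 2-methoxypyrimidin-5-yl with the same group gives a 1.7-fold lower number from compound 1 to compound 3 (0.23 log units; within the scatter), which stays within the scatter, so the 4-cyanophenyl compound stands clearly apart only from compound 2. Nothing available accounts for this step.

Going by these compounds, whether the nitrile or the carbon-only ring matters more remains open. So does whether 4-methoxyphenyl or unsubstituted phenyl here would stay close to compound 2.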